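The source may report more compounds than this note shows. Statements on the series, on what has been measured and on what is new or still open speak of the compounds shown alone.

In a functional assay on A549 cells (Homo sapiens) for antiproliferative activity, read by MTT assay, with a stated time of 72 h (a higher number here means a weaker inhibitor, a lower number a stronger inhibitor), compound 1 `COc1ccc(N2CCN(C(=S)SCc3ccc4nc(N)nc(N)c4c3)CC2)cc1` gives 1590 nM, compound 2 `Cc1ccc(N2CCN(C(=S)SCc3ccc4nc(N)nc(N)c4c3)CC2)cc1` gives 2190 nM and compound 3 `Cc1ccc(N2CCN(C(=S)SCc3ccc4nc(N)nc(N)c4c3)CC2)c(C)c1` gives 3000 nM. Compound 3 is not separated from the other two, since a 1.9-fold higher number from compound 1 to compound 3 (0.28 log units; within the scatter) and a 1.4-fold higher number from compound 2 to compound 3 (0.14 log units; within the scatter) both lie within the scatter. Compound 4 `Nc1nc(N)c2cc(CSC(=S)N3CCN(c4ccccc4F)CC3)ccc2n1` differs from compound 3 by 2-fluorophenyl in place of 2,4-dimethylphenyl on an amine nitrogen in a ring. Among the compounds with values here, no measured compound carries fluorine, so the closest guide is the earlier changes to this aromatic group, a 1.4-fold higher number from compound 1 to compound 2 (0.14 log units; within the scatter) and a 1.4-fold higher number from compound 2 to compound 3 (0.14 log units; within the scatter), which also stayed within the scatter. No step beyond the scatter is therefore expected in this assay. The estimated step is a 1.3-fold lower number from compound 3 to compound 4 (0.12 log units; within the scatter). For compound 4 the expected value is 2300 nM, within an estimated range of 900 nM to 6000 nM.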

Compound 4, half-maximal inhibitory concentration: 6460 nM
For compound 4 the middle estimate is 2.8-fold (0.45 log units) below the measured one; the measured number lies above the stated range.
By their numbers in this assay, from the lowest: compounds 1, 2 and 3 (each within the scatter of the next); then compound 4.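

Earlier changes to the aromatic group on the amine nitrogen in a ring stayed within the scatter in this assay, but 2-fluorophenyl is separated from all three earlier groups, with modest steps (a 2.2-fold higher number from compound 3 to compound 4 (0.33 log units; beyond the scatter); a 2.9-fold higher number from compound 2 to compound 4 (0.47 log units; beyond the scatter); a 4.1-fold higher number from compound 1 to compound 4 (0.61 log units; beyond the scatter)). This position therefore does respond to the group it carries, and here the number rises. Nothing measured here explains the step.

The compounds shown leave open whether the step follows from the fluorine or from the loss of the earlier groups. A plain phenyl or a chlorophenyl at this position would help to separate the two.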